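A few compounds are considered here, and "the series" means these few. Any claim that something is new, unique, unknown or untested is made for them only; others in the source may bear on it.

Measured compounds in a functional assay on NCI-H460 cells (Homo sapiens) for cytotoxicity, read by MTT assay, with a stated time of 72 h; on this read-out higher numbers stand for weaker inhibition and lower numbers for stronger inhibition:
compound 1 `COc1cc2c(Oc3ccc(NC(=O)c4nnn(-c5ccccc5C(F)(F)F)c4C)cc3F)ccnc2cc1OCCCN1CCCC1`: compound 1 gives 230 nM
compound 2 `COc1cc2c(Oc3ccc(NC(=O)c4nnn(-c5ccccc5C(F)(F)F)c4C)cc3F)ccnc2cc1OCCCN1CCCCC1`: compound 2 gives 280 nM

Of the two numbers, compound 2 has the higher one, yet the gap to compound 1 is within the scatter, so the two are not told apart. Compound 3 `COc1cc2c(Oc3ccc(NC(=O)c4nnn(-c5ccccc5C(F)(F)F)c4C)cc3F)ccnc2cc1OCCCN1CCN(C)CC1` is the next member: 4-methylpiperazin-1-yl in place of piperidin-1-yl on a saturated chain carbon, three bonds along the chain from an oxygen on an aromatic ring. Among the measured compounds shown here, the one measured step that bears on this is a change of the same ring on the same chain carbon, which gave a 1.2-fold higher number from compound 1 to compound 2 (0.09 log units; within the scatter). The shared core, the linking chain and the amide part stay untouched in all three compounds. On that basis, swapping one saturated ring for another at the end of the chain is expected to leave the number about where compound 2 stands, with a 1.1-fold higher number from compound 2 to compound 3 (0.03 log units; within the scatter) no larger than the scatter. Compound 3 is therefore estimated at 300 nM, within a range from 120 nM to 750 nM.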

Compound 3, half-maximal inhibitory concentration: 260 nM
Estimate against measurement, compound 3: 1.2-fold (0.06 log units) above, and the stated range covers the measured number.
By their numbers in this assay, from the lowest: compounds 1, 3 and 2 (each within the scatter of the next).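

In this assay, 4-methylpiperazin-1-yl in place of piperidin-1-yl gives a 1.1-fold lower number from compound 2 to compound 3 (0.03 log units; within the scatter) and 4-methylpiperazin-1-yl in place of pyrrolidin-1-yl gives a 1.1-fold higher number from compound 1 to compound 3 (0.05 log units; within the scatter) so all three compounds remain indistinguishable. The earlier pair compared only rings with 1 hetero atom, whereas this result shows that a six-membered ring with 2 hetero atoms, here carrying a methyl group, leaves the number within the scatter at this position on the chain. No measurement shown here explains this lack of separation.

On these data alone, it remains open whether morpholin-4-yl or an open-chain amine such as dimethylamino would also stay within the scatter at the end of the chain. As far as these compounds go, the effect of a carboxylic acid there, or of a longer chain carrying the same rings, is also open.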